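Hydroxy for Fluoro on a Dopamine Receptor Agonist

The source may hold more compounds than are shown below. What is called first, only, known or untested is meant among the compounds shown, and "the series" means these compounds.

Measured compounds:
compound 1, `Cc1cccc(NC(=O)CN2CCC(c3cccc(F)c3)CC2)c1`, 40%
compound 2, `c1ccc(C2CCN(Cc3nc4ccccc4[nH]3)CC2)nc1`, 62%
compound 3, `CC(C)Oc1cccc(NC(=O)CN2CCC(c3cccc[n+]3[O-])CC2)c1`, 48%

Of the compounds shown here, three have been tested in a functional assay on HEK293 cells for agonist activity at D(4) dopamine receptor (Homo sapiens), read by FLIPR; a lower number here means a smaller maximal response, a higher number a larger maximal response. In this assay compound 1 gives 40%, the lowest of the three numbers. Compound 3 comes nearest with 48%, a value within the usual scatter of compound 1, so the two cannot be told apart. Compound 2 gives 62%, which lies beyond the scatter above compound 1.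

The next compound, compound 4, has the structure `Cc1cccc(NC(=O)CN2CCC(c3cccc(O)c3)CC2)c1`. It keeps the core of compound 1 and differs from it in one place: hydroxy in place of fluoro on an aromatic carbon. None of the three measured compounds form a pair that isolates such a change, so nothing measured shows how this assay responds to it. The expectation for compound 4 therefore rests on compound 1 alone, and the step of a number 5 percentage points higher from compound 1 to compound 4 (within the scatter) is expected to be small, most likely within the scatter, with a modest rise somewhat more plausible than a fall. The maximal response of compound 4 is estimated at 45%, with a likely range from 25% to 70%.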

Compound 4, largest response reached (reported as efficacy), in percent of the reference or control that the assay uses: 66%
The estimate for compound 4 lay 21 percentage points below the measured number; the measured number falls inside the stated range.
By their numbers in this assay, from the lowest: compounds 1 and 3 (each within the scatter of the next); then compounds 2 and 4 (each within the scatter of the next).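

In this assay, among the compounds shown here, going from 3-fluorophenyl to 3-hydroxyphenyl gives a number 26 percentage points higher from compound 1 to compound 4 (beyond the scatter), the first pair in the set that isolates a single change, and it shows that the maximal response is sensitive to what sits at this place on the aromatic ring. The exchange keeps the count of heavy atoms the same and leaves the rest of the molecule untouched, while adding one hydrogen-bond donor and one hydrogen-bond acceptor, so the difference in response can be tied to this one swap, though not to any one feature of it. No measurement at hand bears on what lies behind the rise.

A methoxy group, an amine or a carboxylic acid at this same place could show whether the rise is particular to hydroxy or also appears with other groups in place of fluoro. Going by these compounds, whether the same exchange would raise the response on a different core also stays open, since a single pair speaks only for the core of compound 1.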